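The compounds below may be only part of what the source reports. "The series", "measured", "known", "first", "only" and "open" are said of these compounds alone.

Measured so far in a functional assay on THP-1 cells (Homo sapiens) for inhibition, read by ELISA, with stated times of 2 h and 48 h; on this read-out lower numbers stand for stronger inhibition and higher numbers for weaker inhibition:
- compound 1, `CCOC1=C(/C(C)=N/OCC(=O)Nc2cccc(F)c2)N(C)S(=O)(=O)c2ccccc21`: > 20000 nM, a limit of the assay
- compound 2, `CCOC1=C(/C(C)=N/OCC(=O)Nc2cccc(OC)c2)N(C)S(=O)(=O)c2ccccc21`: > 20000 nM, a limit of the assay
- compound 3, `CCOC1=C(/C(C)=N/OCC(=O)Nc2ccc(C(F)(F)F)cc2)N(C)S(=O)(=O)c2ccccc21`: 16700 nM

Compound 2 stands at the limit of this assay, not at a number. Compound 1 sits at the same limit, (the limit of > 20000 nM in this assay, at which 2 of the 3 values shown sit). Compound 3 is the only one of the three with a number, and that number lies close under the limit.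

The next compound, compound 4 `CCOC1=C(/C(C)=N/OCC(=O)Nc2ccc(F)c(Cl)c2)N(C)S(=O)(=O)c2ccccc21`, is compound 2 with one change: 3-chloro-4-fluorophenyl in place of 3-methoxyphenyl on an amide-type nitrogen.

Within the data shown here, two measured steps touch the same position. The step of an at least 1.1-fold lower number from compound 2 to compound 3 (0.07 log units; that floor lies within the scatter) gives only a floor, and that floor lies within the scatter. The step that the two limits leave unreadable from compound 1 to compound 2 runs between two limits and cannot be read. Neither shows a change at this position that rises above the scatter, and a halogen-bearing phenyl on the amide-type nitrogen is already present in compound 1 and compound 3 without moving the value far from the limit. For compound 4 the expected step of an at least 1.1-fold lower number from compound 2 to compound 4 (0.04 log units; that floor lies within the scatter) is therefore none beyond the scatter, and a further limit is the most likely outcome. Compound 4 is estimated at 18000 nM, within 7000 nM to 40000 nM.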

Compound 4, half-maximal inhibitory concentration: > 20000 nM
Compound 4 was reported as a limit; the forecaster's own chance of this, stated with the estimate: 60%; middle value at least 1.1-fold (0.04 log units) away from the limit.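

In this assay compound 4 gives > 20000 nM, which is a limit of the assay and not a number. Among these compounds, with this result, 3-fluorophenyl, 3-methoxyphenyl and 3-chloro-4-fluorophenyl on the amide-type nitrogen all end at the same limit, so a second halogen on the ring brings no readable value under it, and the only measured value in the set remains that of compound 3. The steps to compound 4 from compound 1 and compound 2 cannot be read, while an at least 1.1-fold higher number from compound 3 to compound 4 (0.07 log units; that floor lies within the scatter) gives only a floor, leaving the position without a step beyond the scatter and the series pressed against one ceiling: the limit of > 20000 nM in this assay, at which 3 of the 4 values shown sit.

Open, from the compounds shown here alone, is whether any group on the amide-type nitrogen can bring the value well under the limit, for example a phenyl carrying an amine or a carboxylic acid, or a longer chain in place of the phenyl. Also open, going by these compounds, is how much inhibition depends on the shared core, which is the same in all four compounds, so that the true size of the values now reported as limits stays unknown.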